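One Fluorine Added to an Amide-Bearing Thiazole Acid

The compounds below may be only part of what the source reports. "The series", "measured", "known", "first", "only" and "open" are said of these compounds alone.

Measured compounds:
- compound 1 `CCOC(=O)c1sc(-c2cccc(NC(=O)c3ccc(F)c(Cl)c3)c2)nc1Nc1ccc(N2CCN(C)CC2)cc1` — "not determined" (no result reported)
- compound 2 `CN1CCN(c2ccc(Nc3nc(-c4cccc(NC(=O)c5ccccc5)c4)sc3C(=O)O)cc2)CC1` — "not determined" (no result reported)
- compound 3 `CN1CCN(c2ccc(Nc3nc(-c4cccc(NC(=O)c5ccc(Cl)cc5)c4)sc3C(=O)O)cc2)CC1` — 7020 nM

Among the measured compounds shown here, in a functional assay on Raji cells (Homo sapiens) for antiproliferative activity, read by CCK-8 assay, with a stated time of 72 h (a lower number here means a stronger inhibitor, a higher number a weaker inhibitor), compound 3 gives 7020 nM, the only number available. In this assay compound 1 gives "not determined" (no result reported) and compound 2 gives "not determined" (no result reported), so compound 3 cannot be ranked against anything. Compound 4 `CN1CCN(c2ccc(Nc3nc(-c4cccc(NC(=O)c5ccc(F)c(Cl)c5)c4)sc3C(=O)O)cc2)CC1` differs from compound 3 in one place: 3-chloro-4-fluorophenyl in place of 4-chlorophenyl on a carbonyl carbon. For the measured compounds named here, no measured pair shows what such a change does here. The expected step from compound 3 to compound 4 is a 1.2-fold lower number from compound 3 to compound 4 (0.07 log units; within the scatter), within the usual scatter, with no direction claimed. Compound 4 is therefore estimated at 6000 nM, with a range from 2500 nM to 15000 nM.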

Compound 4, half-maximal inhibitory concentration: 8740 nM
For compound 4 the middle estimate is 1.5-fold (0.16 log units) below the measured one, within the range that was stated.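

In this assay, among the compounds shown here, the first measured pair at this position shows a 1.2-fold higher number from compound 3 to compound 4 (0.10 log units; within the scatter), so 3-chloro-4-fluorophenyl and 4-chlorophenyl on this carbonyl carbon cannot be told apart. Adding one fluorine and shifting the chlorine therefore gives no measurable gain or loss in this pair. No available evidence bears on this result.

Steps involving compound 1 and compound 2 cannot be read, as neither has a number. Also open, as far as these compounds go, is how a pyridine ring or a longer alkyl chain would behave in place of these phenyl groups.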